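The source may hold more compounds than are shown below. What is called first, only, known or untested is meant among the compounds shown, and "the series" means these compounds.

Compound 1 `CCCCOC(=O)NS(=O)(=O)c1sc(CC(C)C)cc1-c1ccc(CN2C(=O)CCC2=O)cc1`; compound 2 `CCCCOC(=O)NS(=O)(=O)c1sc(CC(C)C)cc1-c1ccc(Cn2ncnn2)cc1`; compound 3 `CCCCOC(=O)NS(=O)(=O)c1sc(CC(C)C)cc1-c1ccc(Cn2cccn2)cc1`.

In an assay on membranes from uterus for displacement of a labelled ligand from Angiotensin type II receptor (Sus scrofa), with a stated time of 1.5 h (a lower number here means a stronger inhibitor, a higher number a weaker inhibitor), compound 1 reaches only a limit of the assay, > 10000 nM. Compound 2 gives 16 nM and compound 3 gives 2.3 nM. Compound 3 thus holds the lowest of the two numbers, with a 7.0-fold lower number from compound 2 to compound 3 (0.84 log units; beyond the scatter). Compound 1 sits at the limit of > 10000 nM in this assay, at which 1 of the 3 values shown sits.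

Compound 4 `CCCCOC(=O)NS(=O)(=O)c1sc(CC(C)C)cc1-c1ccc(C(=O)c2nccs2)cc1` differs from compound 3 in one place: (1,3-thiazol-2-yl)carbonyl in place of (1H-pyrazol-1-yl)methyl on an aromatic carbon. All three measured steps vary the group at this position: an at least 620-fold lower number from compound 1 to compound 2 (2.79 log units; beyond the scatter) and an at least 4300-fold lower number from compound 1 to compound 3 (3.63 log units; beyond the scatter) were large, a 7.0-fold lower number from compound 2 to compound 3 (0.84 log units; beyond the scatter) modest. None exchanges the saturated chain carbon for a carbonyl, so they guide only indirectly. Since a five-membered aromatic ring with 2 hetero atoms remains, compound 4 is expected to show an 8.7-fold higher number from compound 3 to compound 4 (0.94 log units; beyond the scatter), a modest weakening. Compound 4 is therefore estimated at 20 nM, ranging from 3 nM to 150 nM.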

Compound 4, inhibition constant: 18.6 nM
The estimate for compound 4 lay 1.1-fold (0.03 log units) above the measured number; the range from low to high includes it.
By their numbers in this assay, from the lowest: compound 3; then compounds 2 and 4 (each within the scatter of the next). At a limit, above all of these: compound 1.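

Compound 4 alone among those shown carries a carbonyl rather than a saturated chain carbon on the aromatic carbon, and in this assay it still binds well, with an 8.1-fold higher number from compound 3 to compound 4 (0.91 log units; beyond the scatter) and a 1.2-fold higher number from compound 2 to compound 4 (0.07 log units; within the scatter). The (1,3-thiazol-2-yl)carbonyl group also stands far from the (2,5-dioxopyrrolidin-1-yl)methyl group, with an at least 530-fold lower number from compound 1 to compound 4 (2.73 log units; beyond the scatter). That step rests on a limit for compound 1, not a number: the limit of > 10000 nM in this assay, at which 1 of the 4 values shown sits.

On these data alone, the step from compound 3 changes the ring and the carbonyl together, so the share of each remains open. Also open, as far as these compounds go, is how an amine or a carboxylic acid would fare on this aromatic carbon.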